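The source may hold more compounds than are shown below. What is called first, only, known or untested is meant among the compounds shown, and "the series" means these compounds.

In a functional assay (trachea) with Cavia porcellus as the target (on this read-out lower numbers stand for stronger inhibition and higher numbers for weaker inhibition), three compounds sharing one core differ only in the group on the chain at the aromatic nitrogen. Compound 1 `O=c1c2ccccc2c(-c2cccnc2)nn1CC1CCCCC1`, with cyclohexyl, gives 209 nM. Compound 2 `O=c1c2ccccc2c(-c2cccnc2)nn1CCSc1nccs1`, with its (1,3-thiazol-2-yl)sulfanyl group, gives 10500 nM, and the change is a 50-fold higher number from compound 1 to compound 2 (1.70 log units; beyond the scatter). Compound 3 `O=C(O)CCCn1nc(-c2cccnc2)c2ccccc2c1=O` reads > 100000 nM, which is a limit of the assay and not a number. It is the weakest of the three, with an at least 470-fold higher number from compound 1 to compound 3 (2.67 log units; beyond the scatter) and an at least 9.5-fold higher number from compound 2 to compound 3 (0.97 log units; beyond the scatter).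

Compound 4 `NCCn1nc(-c2cccnc2)c2ccccc2c1=O` departs from compound 3 by amino in place of carboxymethyl on a saturated chain carbon, two bonds along the chain from an aromatic nitrogen. For the measured compounds named here, no measured step makes this exact exchange. The closest guide is an at least 9.5-fold higher number from compound 2 to compound 3 (0.97 log units; beyond the scatter), made at the same place, while the two large steps away from compound 1 show how much can be lost when cyclohexyl goes. The incoming amino, like the outgoing carboxymethyl, has no ring, although the ring in compound 2 did not preserve the value of compound 1. Only a modest gain toward a lower number is therefore expected, and the expected step is an at least 3.3-fold lower number from compound 3 to compound 4 (0.52 log units; beyond the scatter). For compound 4 the estimated value is 30000 nM, within an expected range of 4000 nM to 100000 nM.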

Compound 4, half-maximal inhibitory concentration: > 100000 nM
Compound 4: a limit, no number; the forecaster's own chance of this, stated with the estimate: 35%; at least 3.3-fold (0.52 log units) between middle value and limit.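

In this assay compound 4 reads > 100000 nM, which is a limit of the assay and not a number. The amino group on this saturated chain carbon, two bonds along the chain from an aromatic nitrogen, leaves a clear gap to both compounds whose groups carry a ring, with an at least 9.5-fold higher number from compound 2 to compound 4 (0.97 log units; beyond the scatter) and an at least 470-fold higher number from compound 1 to compound 4 (2.67 log units; beyond the scatter), so a second group without a ring, built from different atoms than carboxymethyl, now also fails to reach the value of compound 2, itself well short of compound 1. The step between compound 3 and compound 4 cannot be read, and the data do not tell whether amino and carboxymethyl differ at all, because both compounds stand at the same ceiling: the limit of > 100000 nM in this assay, at which 2 of the 4 values shown sit.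

As far as these compounds go, how far beyond that limit compound 3 and compound 4 lie stays open, and so does whether a longer chain ending in an amine or a carboxylic acid would return a readable number. Also open, from the compounds shown here alone, is whether a phenyl ring on the same chain would come closer to cyclohexyl than the (1,3-thiazol-2-yl)sulfanyl group does.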